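This account rests on a few compounds, and the source may have more. Where it says the series, first, only, none or still open, it means among the compounds named here.

Measured so far:
Compound 1, `Cc1ccc(C(=O)NC2=C(C#N)C(c3ccc(Cl)cc3Cl)C3=C(CCCC3=O)N2c2ccc(S(N)(=O)=O)cc2)cc1`: 40%
Compound 2, `N#CC1=C(NC(=O)c2ccc([N+](=O)[O-])cc2)N(c2ccc(S(N)(=O)=O)cc2)C2=C(C(=O)CCC2)C1c1ccc(Cl)cc1Cl`: 50%

In a functional assay on Ehrlich cells (Mus musculus) for cytotoxicity, read by trypan blue exclusion, with a stated time of 2 h, tested at 50 ug/mL (a higher number here means a stronger effect of the compound at the concentration tested, a lower number a weaker effect), compound 2 stands highest of the two numbers, with compound 1 nearest, and the step of a number 10 percentage points higher from compound 1 to compound 2 (within the scatter) lies within the scatter. Compound 3, `CN(C)c1ccc(/C=N/C2=C(C#N)C(c3ccc(Cl)cc3Cl)C3=C(CCCC3=O)N2c2ccc(S(N)(=O)=O)cc2)cc1`, differs from compound 2 in that (a group of 11 heavy atoms (9 carbon, 2 nitrogen; one six-membered aromatic ring of carbon only) in place of a group of 12 heavy atoms (7 carbon, 2 nitrogen, 3 oxygen; one six-membered aromatic ring of carbon only), on a double-bonded ring carbon). Among the measured compounds shown here, the only measured step, a number 10 percentage points higher from compound 1 to compound 2 (within the scatter), concerns another part of the structure and does not bear on this change, so there is no ground to expect a shift beyond the scatter, and the expected step is a number 5 percentage points lower from compound 2 to compound 3 (within the scatter). Compound 3 is therefore estimated at 45%, within a range from 25% to 65%.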

Compound 3, a percentage reported as activity, at one concentration (the size of the read-out at that concentration, not a potency): 30%
Compound 3: the middle estimate sits 15 percentage points above what was measured, within the range that was stated.
By their numbers in this assay, from the lowest: compounds 3, 1 and 2 (each within the scatter of the next, the first and the last beyond it).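

In this assay, among the compounds shown here, the double-bonded ring carbon is the first place where a change goes beyond the scatter: swapping out the ((4-nitrophenyl)carbonyl)amino group gives a number 20 percentage points lower from compound 2 to compound 3 (beyond the scatter). Starting instead from the methyl-bearing group, the same entering group gives a number 10 percentage points lower from compound 1 to compound 3 (within the scatter), so what this swap does depends on the group that leaves. No measurement here accounts for either step. As far as these compounds go, whether a plain amine on this carbon would keep or lose the effect remains open. So does whether the nitro group's place on the aromatic ring matters.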